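The compounds below may be only part of what the source reports. "The series", "measured", "known", "first", "only" and "open" are said of these compounds alone.

Among the compounds with values here, compound 3 `COC(=O)/C=C/c1cccc(N(Cc2ccc(-c3cccc(OC(F)(F)F)c3)cc2)C(=O)C(C)C)c1` gives 247 nM in an assay on isolated protein with Bile acid receptor (Homo sapiens) as the target (a lower number here means that less compound is needed, a higher number that more compound is needed for the effect), the highest of the three numbers measured so far; compound 1 `COC(=O)/C=C/c1cccc(N(Cc2ccc(/C=C/c3c(Cl)cccc3Cl)cc2)C(=O)C(C)C)c1` gives 195 nM and compound 2 `COC(=O)/C=C/c1cccc(N(Cc2ccc(/C=C/c3ccc(F)cc3)cc2)C(=O)C(C)C)c1` gives 120 nM. The gap a 1.3-fold higher number from compound 1 to compound 3 (0.10 log units; within the scatter) lies within the scatter, whereas a 2.1-fold higher number from compound 2 to compound 3 (0.31 log units; beyond the scatter) lies beyond it. Compound 4 `COC(=O)/C=C/c1cccc(N(Cc2ccc(/C=C/c3ccccc3)cc2)C(=O)C(C)C)c1` differs from compound 3 by 2-phenylethenyl in place of 3-(trifluoromethoxy)phenyl on an aromatic carbon. Of the measured steps, a 2.1-fold higher number from compound 2 to compound 3 (0.31 log units; beyond the scatter) bears most directly on this change: that step likewise set 3-(trifluoromethoxy)phenyl in place of a 2-(4-fluorophenyl)ethenyl group, and a 1.3-fold higher number from compound 1 to compound 3 (0.10 log units; within the scatter) points the same way while staying within the scatter. Undoing that exchange, a modest move toward a lower number is expected for compound 4, namely a 1.6-fold lower number from compound 3 to compound 4 (0.22 log units; within the scatter). Compound 4 is therefore estimated at 150 nM, within a range from 70 nM to 330 nM.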

Compound 4, half-maximal effective concentration: 65 nM
The estimate for compound 4 lay 2.3-fold (0.36 log units) above the measured number; measured number outside the range, below it.
By their numbers in this assay, from the lowest: compounds 4, 2, 1 and 3 (each within the scatter of the next, the first and the last beyond it).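

In this assay, within the data shown here, 2-phenylethenyl in place of 3-(trifluoromethoxy)phenyl on this aromatic carbon gives a 3.8-fold lower number from compound 3 to compound 4 (0.58 log units; beyond the scatter), a larger step than the earlier comparisons of these groups showed. On the ethenyl chain, phenyl in place of 2,6-dichlorophenyl gives a 3.0-fold lower number from compound 1 to compound 4 (0.48 log units; beyond the scatter), whereas hydrogen in place of fluoro gives a 1.8-fold lower number from compound 2 to compound 4 (0.27 log units; within the scatter), which stays within the scatter. No available evidence accounts for these differences. Still open, on these data alone, is how an amine or a carboxylic acid on the phenyl of 2-phenylethenyl would fare, and how a longer chain would compare with the ethenyl link.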